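The source may hold more compounds than are shown below. What is called first, only, known or untested is meant among the compounds shown, and "the series" means these compounds.

Measured compounds in a functional assay on MOLT-4 cells (Homo sapiens) for cytotoxicity, read by sulforhodamine B assay, with a stated time of 48 h, tested at 1 uM; a higher number here means a weaker effect of the compound at the concentration tested, a lower number a stronger effect:
compound 1, `COc1cc(-c2cc(/C=C/C(=O)c3ccc(N)cc3)[nH]n2)cc(OC)c1OC`, gives 72%
compound 2, `COc1ccc(C(=O)/C=C/c2cc(-c3cc(OC)c(OC)c(OC)c3)n[nH]2)cc1OC`, gives 88%

Compound 2 holds the higher of the two numbers in this assay; its nearest neighbour is compound 1, and the step of a number 16 percentage points higher from compound 1 to compound 2 (beyond the scatter) is a modest one, brought by 3,4-dimethoxyphenyl in place of 4-aminophenyl on a carbonyl carbon.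

Compound 3, `COc1ccc(C(=O)/C=C/c2cc(-c3cc(OC)c(OC)c(OC)c3)n[nH]2)cc1`, is not yet measured. It differs from compound 2 as follows: hydrogen in place of methoxy on an aromatic carbon. Among the compounds with values here, no measured step bears directly on this change: the single step known, from compound 1 to compound 2, exchanges the whole aryl group on the carbonyl carbon rather than removing one methoxy from it, so it gives no guide to the size or direction here. Both measured numbers sit in the upper part of the scale. On this thin basis no step beyond the scatter is expected, and the estimated step of a number 3 percentage points lower from compound 2 to compound 3 (within the scatter) is set close to zero with a wide allowance either way. Compound 3 is therefore estimated at 85%, between 65% and 100%.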

Compound 3, a percentage reported as activity, at one concentration (the size of the read-out at that concentration, not a potency): 102%
The estimate for compound 3 lay 17 percentage points below the measured number; the whole stated range lies below it.
By their numbers in this assay, from the lowest: compound 1; then compound 2; then compound 3.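

In this assay, the loss of one methoxy, ortho to a methoxy group and meta to a large group, is not a neutral change: 3,4-dimethoxyphenyl to 4-methoxyphenyl gives a number 14 percentage points higher from compound 2 to compound 3 (beyond the scatter), so this single position on the aryl group at the carbonyl carbon affects the read-out, which the earlier whole-group exchange could not show. A second change at one place, methoxy in place of amino on an aromatic carbon, gives a number 30 percentage points higher from compound 1 to compound 3 (beyond the scatter), and among these three compounds the effect weakens in the order 4-aminophenyl, 3,4-dimethoxyphenyl, 4-methoxyphenyl. No measurement at hand explains either step.

Open, as far as these compounds go, is whether the stronger effect of compound 1 depends on the amino group itself or would also appear with a hydroxy, acetamido or dimethylamino group on the same aromatic carbon. Also open, from the compounds shown here alone, is whether an ethoxy group or a chlorine atom in place of the lost methoxy would move the number back toward that of compound 2, and whether the order of stronger and weaker effects seen at the concentration tested would hold at other concentrations.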